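Compound 4: phenyl to 4-fluorocyclohexyl, expected half-life

The compounds below may be only part of what the source reports. "The series", "measured", "known", "first", "only" and "open" are said of these compounds alone.

In an ADME assay on microsomes from liver (Rattus norvegicus, strain Sprague-Dawley) for metabolic stability, read by LC-MS, using NADPH, with a stated time of 45 min, tested at 3 uM (on this read-out lower numbers stand for a shorter-lived compound and higher numbers for a longer-lived compound), compound 2 `c1ccc(C(CC2CCCCN2)C2CCCCC2)cc1` gives 0.0667 h. Compound 1 `C1CCC(C(CC2CCCCN2)C2CC2)CC1` gives 0.05 h, within the scatter of compound 2. Compound 3 `CC1(C)CCC(C(CC2CCCCN2)C2CCCCC2)CC1` gives 0.333 h, clearly higher than the other two. Compound 4 `FC1CCC(C(CC2CCCCN2)C2CCCCC2)CC1` is the next to be read in this assay.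

The change from compound 2 is 4-fluorocyclohexyl in place of phenyl on a saturated chain carbon bound to a saturated chain carbon and a saturated ring carbon. Going by the values given here, the only measured step at this place is a 1.3-fold higher number from compound 1 to compound 2 (0.13 log units; within the scatter), which stays within the scatter. It involves no fluorine, so it bears only loosely on the change. Among the compounds with values here, no single-place step connects compound 3 to compound 2, but compound 3 at 0.333 h shows that a higher number is reachable.

A modest rise is therefore expected, close to the edge of the scatter. The expected step is a 2.1-fold higher number from compound 2 to compound 4 (0.32 log units; beyond the scatter). For compound 4 the estimated half-life is 0.14 h, with an expected range of 0.06 h to 0.35 h.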

Compound 4, half-life: 0.183 h
Compound 4: the middle estimate sits 1.3-fold (0.12 log units) below what was measured; the range from low to high includes it.
By their numbers in this assay, from the lowest: compounds 1 and 2 (each within the scatter of the next); then compounds 4 and 3 (each within the scatter of the next).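

The position on a saturated chain carbon bound to a saturated chain carbon and a saturated ring carbon now shows a change beyond the scatter in this assay, which the earlier step there did not: 4-fluorocyclohexyl in place of phenyl gives (a 2.7-fold higher number from compound 2 to compound 4 (0.44 log units; beyond the scatter)). 4-fluorocyclohexyl in place of cyclopropyl points the same way and also lies beyond the scatter (a 3.7-fold higher number from compound 1 to compound 4 (0.56 log units; beyond the scatter)). No measurement bears on the reason for these rises.

The two steps do not separate the part played by the fluorine from that of the saturated ring, and unsubstituted cyclohexyl at this place would divide the two. Going by these compounds, whether a second fluorine on that ring, as in 4,4-difluorocyclohexyl, would move the half-life further also remains open.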